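Pyridin-4-yl for phenyl: efficacy notes on the series

A few compounds are considered here, and "the series" means these few. Any claim that something is new, unique, unknown or untested is made for them only; others in the source may bear on it.

Measured so far:
compound 1 `O=C(O)Cc1sc(C(c2ccc(F)cc2)c2ccc(F)cc2)nc1-c1ccccc1` — 80%
compound 2 `O=C(O)Cc1sc(C(c2ccccc2)c2ccccc2)nc1-c1ccc(C(F)(F)F)cc1` — 80%
compound 3 `O=C(O)Cc1sc(C(c2ccccc2)c2ccccc2)nc1-c1ccc(F)c(F)c1` — 80%

In an in vitro functional assay on HEK285-7 cells for antagonist activity at prostaglandin D2 receptor 2 (Homo sapiens), read by BRET and beta-arrestin recruitment (a lower number here means a smaller maximal response, a higher number a larger maximal response), compound 1 gives 80%, level with compounds 2 and 3 within the scatter. Within the data shown here, the only measured step, no change at the digits printed from compound 2 to compound 3 (within the scatter), changes the group on another aromatic carbon, not the one altered here, so it bears only indirectly; it shows that the maximal response has stayed flat across the three compounds.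

Compound 4 `O=C(O)Cc1sc(C(c2ccc(F)cc2)c2ccc(F)cc2)nc1-c1ccncc1` differs from compound 1 by pyridin-4-yl in place of phenyl on an aromatic carbon. Among the measured compounds shown here, no measured step exchanges the ring at this place, so the expectation rests on the flat run alone. The step is expected to stay within the scatter, no change at the digits printed from compound 1 to compound 4 (within the scatter). Compound 4 is therefore estimated at 80%, with a range from 66% to 92%.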

Compound 4, largest response reached (reported as efficacy), in percent of the reference or control that the assay uses: 80%
For compound 4 middle estimate and measured number coincide at the digits printed; the measured number falls inside the stated range.
By their numbers in this assay, from the lowest: compounds 1, 2, 3 and 4 (each within the scatter of the next).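

In this assay, among these compounds, pyridin-4-yl in place of phenyl is the only exchange of the whole ring at this place, on the aromatic carbon next to the ring nitrogen, and it reads no change at the digits printed from compound 1 to compound 4 (within the scatter). The hydrogen-bond acceptor that enters with pyridin-4-yl therefore leaves the maximal response level here. Nothing on hand accounts for this result.

Open, from the compounds shown here alone, is whether pyridin-3-yl or pyridin-2-yl at this place would stay level too. Also open, going by these compounds, is what an amine on this ring would do, or a longer acid chain in place of the carboxymethyl group.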